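Changing the group at the carbonyl of compound 2

The source may hold more compounds than are shown below. What is called first, only, known or untested is meant among the compounds shown, and "the series" means these compounds.

Compound 1 `CN1CCN(C(=O)NC2CCN(Cc3ccn(-c4ccc(C(F)(F)F)cc4)c3)CC2)C(c2ccccc2)C1`: 28 nM
Compound 2 `O=C(NC1CCN(Cc2ccn(-c3ccc(C(F)(F)F)cc3)c2)CC1)N1CC[C@@H](O)C1`: 138 nM
Compound 3 `O=C(NC1CCN(Cc2ccn(-c3ccc(C(F)(F)F)cc3)c2)CC1)N1CCC(c2ccccc2O)CC1`: 36 nM

In an assay on HEK293 cells for displacement of a labelled ligand from melanin-concentrating hormone receptor 1 (Homo sapiens) (on this read-out higher numbers stand for weaker inhibition and lower numbers for stronger inhibition), compound 2 gives the highest of the three numbers. Its nearest neighbour is compound 3, whose number is lower by a margin beyond the scatter, and compound 1 lies further away still, also beyond the scatter. Compound 4 `O=C(NC[C@H]1CCCC[C@H]1O)NC1CCN(Cc2ccn(-c3ccc(C(F)(F)F)cc3)c2)CC1` differs from compound 2 in one place: ((2-hydroxycyclohexyl)methyl)amino in place of 3-hydroxypyrrolidin-1-yl on a carbonyl carbon. Going by the values given here, no measured pair shows this change, so the expectation rests on compound 2 alone, whose 138 nM is the anchor. A small step is expected, a 1.4-fold lower number from compound 2 to compound 4 (0.14 log units; within the scatter), which stays within the scatter. Compound 4 is expected to give 100 nM in this assay, with a range from 30 nM to 350 nM.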

Compound 4, half-maximal inhibitory concentration: 63 nM
For compound 4 the middle estimate is 1.6-fold (0.20 log units) above the measured one; the measured number falls inside the stated range.
By their numbers in this assay, from the lowest: compounds 1, 3 and 4 (each within the scatter of the next, the first and the last beyond it); then compound 2.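

In this assay, ((2-hydroxycyclohexyl)methyl)amino in place of 3-hydroxypyrrolidin-1-yl on the carbonyl carbon gives a 2.2-fold lower number from compound 2 to compound 4 (0.34 log units; beyond the scatter), a modest step. Going by these compounds alone, this is the first one-place step read at this position, and it shows that the carbonyl carbon accepts an amino-linked carbon ring in place of the pyrrolidine without the number rising. Nothing on hand explains the step.

Still open, on these data alone, is what the hydroxyl contributes to this step, which a methoxy group or an amine at that ring carbon would test. As far as these compounds go, the role of the two defined stereocentres also remains open.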